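A few compounds are considered here, and "the series" means these few. Any claim that something is new, unique, unknown or untested is made for them only; others in the source may bear on it.

In a functional assay on HL-60 cells (Homo sapiens) for inhibition, read by MTT assay, with a stated time of 72 h (a higher number here means a weaker inhibitor, a lower number a stronger inhibitor), compound 1 `Cc1nc(-c2ccccc2)c(C(=O)N2CCN(c3cccc(Cl)c3Cl)CC2)o1` gives 133 nM and compound 2 `CCc1nc(-c2ccc(F)cc2)c(C(=O)N2CCN(c3cccc(Cl)c3)CC2)o1` gives 169 nM as its result. These two numbers lie within the usual scatter of each other, so neither compound can be ranked ahead of the other. Compound 3 `Cc1nc(-c2ccccc2)c(C(=O)N2CCN(c3ccccc3Cl)CC2)o1` differs from compound 1 at one place hydrogen in place of chloro on an aromatic carbon where 2,3-dichlorophenyl becomes 2-chlorophenyl, with hydrogen in place of chloro on an aromatic carbon. Among the measured compounds shown here, no measured pair shows this change on its own, so its size has to be judged without a direct precedent. A small shift toward a higher number, meaning a somewhat weaker inhibitor, is expected, around the size of the scatter or slightly more. The estimated change is a 1.9-fold higher number from compound 1 to compound 3 (0.27 log units; within the scatter) on this reasoning. For compound 3 the estimated value is 250 nM with an expected range from 90 nM to 700 nM once it is measured.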

Compound 3, half-maximal inhibitory concentration: 124 nM
Compound 3: middle estimate off by 2.0-fold (0.30 log units), on the high side; the measured number falls inside the stated range.
By their numbers in this assay, from the lowest: compounds 3, 1 and 2 (each within the scatter of the next).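

Replacing chloro with hydrogen on an aromatic carbon, which turns 2,3-dichlorophenyl into 2-chlorophenyl, gives a 1.1-fold lower number from compound 1 to compound 3 (0.03 log units; within the scatter) in this assay. At this position, then, the chloro group can give way to hydrogen without a readable change in this assay, so this one chlorine atom is not needed to keep the number where it stands in compound 1. Nothing available here accounts for this result.

Among the compounds shown here, it remains open whether the other chloro group, the one still present in compound 3, matters in the same way. It is also open whether a methoxy group or an amine at the position freed in compound 3 would leave the number just as unmoved, since hydrogen is the only replacement for chloro shown here.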